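Aryl swap on the hydrazone nitrogen: compound 3 to compound 4

This account rests on a few compounds, and the source may have more. Where it says the series, first, only, none or still open, it means among the compounds named here.

Three compounds have been measured in an ADME assay on Vero cells (Chlorocebus sabaeus) for cytotoxicity, read by fluorescence and resazurin assay, with a stated time of 3 days; on this read-out lower numbers stand for higher toxicity in this test and higher numbers for lower toxicity in this test:

compound 1, `CC(=O)C[C@H]1O[C@@H](On2cc(CN3C(=O)/C(=N\Nc4ccc(Br)cc4)c4ccccc43)nn2)[C@H](OC(C)=O)[C@@H](OC(C)=O)[C@@H]1OC(C)=O`, gives 116000 nM
compound 2, `CC(=O)C[C@H]1O[C@@H](On2cc(CN3C(=O)/C(=N\Nc4ccc(C#N)cc4)c4ccccc43)nn2)[C@H](OC(C)=O)[C@@H](OC(C)=O)[C@@H]1OC(C)=O`, gives 75400 nM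
compound 3, `CC(=O)C[C@H]1O[C@@H](On2cc(CN3C(=O)/C(=N\Nc4ccc(F)cc4)c4ccccc43)nn2)[C@H](OC(C)=O)[C@@H](OC(C)=O)[C@@H]1OC(C)=O`, gives 68700 nM

Compound 3 has the lowest of the three numbers, but the steps of a 1.7-fold lower number from compound 1 to compound 3 (0.23 log units; within the scatter) and a 1.1-fold lower number from compound 2 to compound 3 (0.04 log units; within the scatter) both fall within the scatter, so compound 3 cannot be set apart from compound 1 or compound 2 on these data.

Compound 4, `CC(=O)C[C@H]1O[C@@H](On2cc(CN3C(=O)/C(=N\Nc4cccc(Cl)c4)c4ccccc43)nn2)[C@H](OC(C)=O)[C@@H](OC(C)=O)[C@@H]1OC(C)=O`, has not yet been measured in this assay. It differs from compound 3 in one place: 3-chlorophenyl in place of 4-fluorophenyl on an amine nitrogen. All three measured steps, a 1.5-fold lower number from compound 1 to compound 2 (0.19 log units; within the scatter), a 1.7-fold lower number from compound 1 to compound 3 (0.23 log units; within the scatter) and a 1.1-fold lower number from compound 2 to compound 3 (0.04 log units; within the scatter), are exchanges of the group on the same aromatic ring attached to the amine nitrogen, and each of them stayed within the scatter. None of them involves a chlorine or a change from 4-fluorophenyl to 3-chlorophenyl, so the step to compound 4 is only partly covered, but what is covered points to a small move.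

The step of a 1.2-fold higher number from compound 3 to compound 4 (0.07 log units; within the scatter) is therefore expected to lie within the scatter. Compound 4 is expected to give about 80000 nM in this assay, within a range from 40000 nM to 160000 nM.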

Compound 4, half-maximal cytotoxic concentration: 117000 nM
The estimate for compound 4 lay 1.5-fold (0.17 log units) below the measured number; the measured number falls inside the stated range.
By their numbers in this assay, from the lowest: compounds 3, 2, 1 and 4 (each within the scatter of the next).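

In this assay the amine nitrogen now carries 3-chlorophenyl, and the three steps to this group, a 1.7-fold higher number from compound 3 to compound 4 (0.23 log units; within the scatter) and a 1.6-fold higher number from compound 2 to compound 4 (0.19 log units; within the scatter) and a 1.0-fold higher number from compound 1 to compound 4 (0.00 log units; within the scatter), all lie within the scatter. Within the data shown here, the earlier compounds exchanged only 4-bromophenyl, 4-cyanophenyl and 4-fluorophenyl, so compound 4 is the first to show that a group with a different name pattern, 3-chlorophenyl, also cannot be set apart from them on this read-out, which extends the flat picture at this position to four aryl groups. No measurement at hand explains this result.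

The change from compound 3 to compound 4 alters the halogen and its place on the ring together, so 4-chlorophenyl and 3-fluorophenyl would be needed to tell those two parts apart. Going by these compounds, it also stays open whether this position remains as undemanding with an amine or a carboxylic acid on the ring, or with an unsubstituted phenyl, and whether the same holds once the acetate esters on the shared core are replaced by free hydroxyl groups.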